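Methoxymethyl for cyano on the imidazole-bound side chain

The source may report more compounds than this note shows. Statements on the series, on what has been measured and on what is new or still open speak of the compounds shown alone.

Measured so far:
compound 1 `CCCn1c(=O)n(CCO)c(=O)c2[nH]cnc21` gives 50000 nM in an assay on Cerebral cortex for binding affinity to adenosine receptor A1 (Cavia porcellus), read by radioligand binding; a higher number here means a weaker inhibitor, a lower number a stronger inhibitor;
compound 2 `CCCn1c(=O)n(CCCO)c(=O)c2[nH]cnc21` gives 12000 nM in this assay;
compound 3 `CCCn1c(=O)n(C)c(=O)c2c1ncn2CC#N` gives 6600 nM in this assay.

Compound 3 stands apart from compound 1 by a gap beyond the scatter, while compound 2 and compound 3 lie within the scatter of each other, so no order between those two can be read. Compound 4 `CCCn1c(=O)n(C)c(=O)c2c1ncn2CCOC` differs from compound 3 by one change: methoxymethyl in place of cyano on a saturated chain carbon bound to an aromatic nitrogen. For the measured compounds named here, the only measured step, a 4.2-fold lower number from compound 1 to compound 2 (0.62 log units; beyond the scatter), concerns a chain on a different ring nitrogen of the shared core, where an extra chain carbon before a hydroxy lowered the number; it does not touch the cyano-to-methoxymethyl exchange, and it offers at best a hint that small changes on a side chain move this assay by modest amounts. Going by the values given here, no measured pair tells what a methoxymethyl does where a cyano stood. The expectation is therefore a step of modest size or none beyond the scatter, with a wide range, and compound 4 is estimated at 8000 nM (range 2500 nM to 25000 nM), which means an expected step of a 1.2-fold higher number from compound 3 to compound 4 (0.08 log units; within the scatter).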

Compound 4, inhibition constant: 12400 nM
Compound 4: the middle estimate sits 1.6-fold (0.19 log units) below what was measured, and the stated range covers the measured number.
By their numbers in this assay, from the lowest: compounds 3, 2 and 4 (each within the scatter of the next); then compound 1.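

In this assay the exchange of cyano for methoxymethyl on a saturated chain carbon bound to an aromatic nitrogen gives a 1.9-fold higher number from compound 3 to compound 4 (0.27 log units; within the scatter) and so stays within the scatter, which means this pair shows no difference that can be read. For the compounds shown here, this is the first pair with a change at this place, and it shows that cyanomethyl and 2-methoxyethyl cannot be told apart here, even though the triple bond is lost and the group entering has more heavy atoms than the one leaving, while the count of hydrogen-bond donors and acceptors stays the same. No supporting measurement bears on this result, so it remains an observation about a single pair.

The compounds shown leave open whether an amine, a carboxylic acid or a longer chain at this place would move the number beyond the scatter, or whether the place tolerates such groups as it does these two. They also leave open whether the same exchange would stay within the scatter on a core carrying a different group on its other ring nitrogen.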